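Hydrogen in Place of tert-Butyl on the Amide-Type Nitrogen

The source may report more compounds than this note shows. Statements on the series, on what has been measured and on what is new or still open speak of the compounds shown alone.

Of the compounds shown here, three have so far been tested in a functional assay on RPMI-8226 cells (Homo sapiens) for inhibition; a lower number here means a stronger inhibitor, a higher number a weaker inhibitor. Compound 1 `CCCCNC(=O)N1CC1C#N` gives 17000 nM, compound 3 `CCOC(=O)c1ccc(NC(=O)N2CC2C#N)cc1` gives 3000 nM, and compound 2 `CC(C)(C)NC(=O)N1CC1C#N` gives 216000 nM. Compound 2 therefore stands at the highest number of the three, beyond the scatter from both compound 1 and compound 3. For the measured compounds named here, the only single-point step among the measured compounds leads to it: a 13-fold higher number from compound 1 to compound 2 (1.10 log units; beyond the scatter).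

Compound 4 `N#CC1CN1C(N)=O` differs from compound 2 by hydrogen in place of tert-butyl on an amide-type nitrogen. The step from compound 1 to compound 2 is the one that bears on this change, since it also alters the group on that nitrogen, and it was large. It shows that the number in this assay moves strongly with that group, but it does not show where a bare hydrogen lands; compound 3, with an aryl group there, shows the lowest number of the three. Compound 4 is thus expected to give a lower number than compound 2, with wide uncertainty. Compound 4 is estimated at 50000 nM, within a range from 8000 nM to 300000 nM. That estimate corresponds to an expected step of a 4.3-fold lower number from compound 2 to compound 4 (0.64 log units; beyond the scatter).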

Compound 4, half-maximal inhibitory concentration: 432000 nM
Compound 4: the middle estimate sits 8.6-fold (0.94 log units) below what was measured; the measured number lies above the stated range.
By their numbers in this assay, from the lowest: compound 3; then compound 1; then compounds 2 and 4 (each within the scatter of the next).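

In this assay, taking the group off the amide-type nitrogen altogether gives a 2.0-fold higher number from compound 2 to compound 4 (0.30 log units; within the scatter) and so leaves hydrogen and tert-butyl at this place indistinguishable, which means that the large step seen earlier with this nitrogen does not continue as a trend as the group is stripped away. For the compounds shown here, the same hydrogen set against butyl gives a 25-fold higher number from compound 1 to compound 4 (1.41 log units; beyond the scatter) and shows that, among the single changes on this nitrogen, a straight butyl chain stands apart from both hydrogen and tert-butyl. No available evidence accounts for this result.

The compounds shown leave open how a shorter or longer straight chain would read on this nitrogen. They also leave open whether the aryl group of compound 3 would keep its number with a plain phenyl ring or with a carboxylic acid in place of the ethyl ester.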